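Swapping a fluorobenzyl for a pyridinylethyl on sulfur

This account rests on a few compounds, and the source may have more. Where it says the series, first, only, none or still open, it means among the compounds named here.

Measured compounds:
- compound 1 `O=c1c2cn(C3COC3)nc2nc(SCc2cccc(F)c2)n1-c1ccccc1`: 5000 nM
- compound 2 `Cn1ncc2c(=O)n(-c3ccccc3)c(/C=C/c3cccc(F)c3)nc21`: 4000 nM
- compound 3 `Cn1ncc2c(=O)n(-c3ccccc3)c(CNc3cccc(F)c3)nc21`: 64000 nM

Of the compounds shown here, three have been tested in a physicochemical assay for solubility, using the shake flask method, in phosphate buffer, with a stated time of 24 h, at pH 7.4; on this read-out lower numbers stand for lower solubility and higher numbers for higher solubility. Compound 1 gives 5000 nM, the second highest of the three numbers. Its nearest neighbour is compound 2, whose value lies within the usual scatter of compound 1, so the two cannot be told apart. Compound 3 stands furthest away, with a value beyond the scatter above compound 1.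

Compound 4 `CC(Sc1nc2nn(C3COC3)cc2c(=O)n1-c1ccccc1)c1ccccn1` has not yet been measured. It differs from compound 1 in one place: 1-(pyridin-2-yl)ethyl in place of 3-fluorobenzyl on a sulfur. The entering group brings one hydrogen-bond acceptor where the leaving group had none, and it carries a ring with one hetero atom rather than a ring of carbon only. Within the data shown here, no measured pair shows this exact change, so there is no directly comparable step. In this assay the step of a 2.4-fold higher number from compound 1 to compound 4 (0.38 log units; beyond the scatter) is expected to be a modest rise, possibly just beyond the scatter. Compound 4 is therefore estimated at 12000 nM, with a likely range from 4000 nM to 40000 nM.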

Compound 4, solubility: 60000 nM
Beside the measured number, compound 4's estimate is 5.0-fold (0.70 log units) below it, outside the stated range (above it).
By their numbers in this assay, from the lowest: compounds 2 and 1 (each within the scatter of the next); then compounds 4 and 3 (each within the scatter of the next).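

In this assay, putting 1-(pyridin-2-yl)ethyl in place of 3-fluorobenzyl on a sulfur gives a 12-fold higher number from compound 1 to compound 4 (1.08 log units; beyond the scatter), a large step. This shows that the read-out responds strongly to the group on this sulfur, even though the two groups have the same count of heavy atoms. The swap changes several things at once, including the loss of fluorine, the arrival of a ring hetero atom and a hydrogen-bond acceptor, and nothing available here says which of these accounts for the step.

The compounds shown leave open whether the pyridine ring or the ethyl branching carries the rise, a question that pyridin-2-ylmethyl and 1-(3-fluorophenyl)ethyl on the same sulfur would separate. They also leave open how a group such as a carboxylic acid or an amine would behave there.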